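Glycine transporter 1 series: chloro in place of methyl

The compounds below may be only part of what the source reports. "The series", "measured", "known", "first", "only" and "open" are said of these compounds alone.

Measured so far:
compound 1 `Cc1nnc(-c2ccc(-c3ccncc3)cc2)n1-c1ccccc1F` — 5900 nM
compound 2 `CCc1nnc(-c2ccc(-c3ccccc3)cc2)n1-c1cccc(C)c1C` — 940 nM

In an assay on C6 glioma cells for displacement of a labelled ligand from sodium- and chloride-dependent glycine transporter 1 (Rattus norvegicus), read by scintillation counting, with stated times of 30 min and 10 min (on this read-out lower numbers stand for stronger inhibition and higher numbers for weaker inhibition), compound 2 gives 940 nM and stands lowest of the two numbers. Compound 1 gives 5900 nM in this assay, a higher number beyond the scatter. Compound 3 `CCc1nnc(-c2ccc(-c3ccccc3)cc2)n1-c1cccc(Cl)c1C` differs from compound 2 only by chloro in place of methyl on an aromatic carbon. Among the compounds with values here, no measured pair shows this change, so the step of a 1.3-fold lower number from compound 2 to compound 3 (0.13 log units; within the scatter) is expected to be small, within the scatter or a slight lowering. Compound 3 is estimated at 700 nM, with a range from 250 nM to 2500 nM.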

Compound 3, half-maximal inhibitory concentration: 2200 nM
Estimate against measurement, compound 3: 3.1-fold (0.50 log units) below; the range from low to high includes it.
By their numbers in this assay, from the lowest: compound 2; then compound 3; then compound 1.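

Chloro in place of methyl on this aromatic carbon, ortho to a methyl group, gives the first single-place comparison in the series: in this assay it reads as a 2.3-fold higher number from compound 2 to compound 3 (0.37 log units; beyond the scatter). This position is therefore sensitive to the change, and the 2,3-dimethylphenyl of compound 2 reads better than the 3-chloro-2-methylphenyl of compound 3. Nothing at hand accounts for the step.

Open, as far as these compounds go, is how a methoxy, an amine or a longer chain would read at this place. Also open, from the compounds shown here alone, is whether chloro in place of the remaining methyl would move the number the same way.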